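Replacing 3-bromophenyl with 4-methylphenyl: working notes

This account rests on a few compounds, and the source may have more. Where it says the series, first, only, none or still open, it means among the compounds named here.

In a functional assay on K562 cells (Homo sapiens) for antiproliferative activity, read by trypan blue exclusion, with a stated time of 48 h, tested at 10 uM (on this read-out lower numbers stand for less inhibition of growth and higher numbers for more inhibition of growth at the one concentration tested), compound 1 (`Cc1ccc(/C=C/C(=O)Nc2ccc(Cl)cc2C(N)=O)cc1`) gives 64% and compound 2 (`NC(=O)c1cc(Br)ccc1NC(=O)/C=C/c1cccc(Br)c1`) gives 45.9%. Compound 2 is therefore the lower of the two measured compounds, and the gap between them lies beyond the usual scatter. The next compound, compound 3 (`Cc1ccc(/C=C/C(=O)Nc2ccc(Br)cc2C(N)=O)cc1`), differs from compound 2 in one place: 4-methylphenyl in place of 3-bromophenyl on a double-bonded chain carbon bound to a double-bonded chain carbon. Among the measured compounds shown here, no measured pair isolates this change, so this assay offers no direct precedent for the size of the step. For the measured compounds named here, the only guide is compound 1, which also carries 4-methylphenyl and gives 64%. On that evidence, a moderate upward step is expected, at the edge of the scatter, and growth inhibition is expected to rise rather than fall. The estimated change is a number 12.1 percentage points higher from compound 2 to compound 3 (beyond the scatter). For compound 3 the estimated value is 58%, with an expected range of 43% to 73%.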

Compound 3, percent growth inhibition at one concentration: 45.9%
For compound 3 the middle estimate is 12.1 percentage points above the measured one, and the stated range covers the measured number.
By their numbers in this assay, from the lowest: compounds 2 and 3 (each within the scatter of the next); then compound 1.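

In this assay, 4-methylphenyl in place of 3-bromophenyl on a double-bonded chain carbon bound to a double-bonded chain carbon gives no change at the digits printed from compound 2 to compound 3 (within the scatter), so with bromo on the shared core the two aryl groups cannot be told apart at this position. Among the compounds shown here, with 4-methylphenyl held constant, bromo in place of chloro on an aromatic carbon gives a number 18.1 percentage points lower from compound 1 to compound 3 (beyond the scatter), which is the first single-place step to lie beyond the scatter. No measurement at hand accounts for either step.

Going by these compounds, whether the two aryl groups would also match with chloro on the shared core remains open, as only bromo-bearing compounds isolate that exchange. Also open, on these data alone, is how a ring carrying an amine or a carboxylic acid at this position would read out.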